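Hydrogen for fluoro on compound 2

The source may hold more compounds than are shown below. What is called first, only, known or untested is meant among the compounds shown, and "the series" means these compounds.

In a functional assay on CCRF-CEM cells (Homo sapiens) for cytotoxicity, in the absence of a further agent (on this read-out lower numbers stand for stronger inhibition and higher numbers for weaker inhibition), compound 1 (`CC(C)(C)OC(=O)CCC(Nc1ccc(CN(CCCc2c(N)nc(N)nc2O)c2cc(F)c([N+](=O)[O-])cc2[N+](=O)[O-])cc1)C(=O)OC(C)(C)C`) gives 1500 nM and compound 2 (`CC(C)(C)OC(=O)CCC(Nc1ccc(CN(CCCc2c(N)nc(N)nc2O)c2cc(F)cc(F)c2[N+](=O)[O-])cc1)C(=O)OC(C)(C)C`) gives 2400 nM, two values within the usual scatter of each other. In this assay, compound 3 (`Nc1nc(N)c(CCCN(Cc2ccc(NC(CCC(=O)O)C(=O)O)cc2)c2cc(F)cc(F)c2[N+](=O)[O-])c(O)n1`) gives > 100000 nM, which is a limit of the assay. Compound 4 (`CC(C)(C)OC(=O)CCC(Nc1ccc(CN(CCCc2c(N)nc(N)nc2O)c2cc(F)ccc2[N+](=O)[O-])cc1)C(=O)OC(C)(C)C`) departs from compound 2 by a single change, hydrogen in place of fluoro on an aromatic carbon, ortho to a nitro group, turning 3,5-difluoro-2-nitrophenyl into 5-fluoro-2-nitrophenyl. Among the compounds with values here, no measured pair isolates this change, so the expectation in this assay starts from compound 2 at 2400 nM, with an expected step that stays within the scatter. The expected step is a 1.2-fold lower number from compound 2 to compound 4 (0.08 log units; within the scatter). The estimate for compound 4 is 2000 nM, with an expected range of 800 nM to 5000 nM.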

Compound 4, half-maximal inhibitory concentration: 12000 nM
Beside the measured number, compound 4's estimate is 6.0-fold (0.78 log units) below it, outside the stated range (above it).
By their numbers in this assay, from the lowest: compounds 1 and 2 (each within the scatter of the next); then compound 4. At a limit, above all of these: compound 3.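

In this assay, hydrogen in place of fluoro on this aromatic carbon, ortho to a nitro group, is not the silent change it might have seemed: it gives a 5.0-fold higher number from compound 2 to compound 4 (0.70 log units; beyond the scatter). Hydrogen in place of nitro gives an 8.0-fold higher number from compound 1 to compound 4 (0.90 log units; beyond the scatter), so a substituent on this carbon counts in both pairs. Nothing shown here accounts for these steps. On these data alone, whether a chloro or a methoxy group on this carbon would keep the level of compound 2 stays open. So does whether a cyano group could stand in for either substituent.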